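Trimethoxy styryl sulfonamides and a cytotoxicity assay on leukemia cells

This account rests on a few compounds, and the source may have more. Where it says the series, first, only, none or still open, it means among the compounds named here.

Three compounds have been measured so far:

Compound 1, `COc1ccc(NS(=O)(=O)/C=C/c2ccc(OC)cc2OC)cc1`: 15000 nM
Compound 2, `COc1ccc(NS(=O)(=O)/C=C/c2c(OC)cc(O)cc2OC)cc1`: 10000 nM
Compound 3, `COc1cc(OC)c(/C=C/S(=O)(=O)Nc2ccc(OC)c(O)c2)c(OC)c1`: 15 nM

All three were tested in a functional assay on K562 cells (Homo sapiens) for cytotoxicity, read by trypan blue exclusion, with a stated time of 96 h; a lower number here means a stronger inhibitor, a higher number a weaker inhibitor. Compound 1 gives 15000 nM and compound 2 gives 10000 nM in this assay, two numbers that sit close together. Compound 3 stands apart: in this assay compound 3 gives 15 nM, the lowest of the three numbers, far beyond the scatter from both others. Compound 3 differs from compounds 1 and 2 in more than one place, so no single change can be credited for its standing.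

The next compound, compound 4, `COc1cc(OC)c(/C=C/S(=O)(=O)Nc2ccc(OC)c(NC(C(=O)O)c3ccc(F)cc3)c2)c(OC)c1`, keeps the shared core of compound 3 and changes one thing: (carboxy(4-fluorophenyl)methyl)amino in place of hydroxy on an aromatic carbon. Within the data shown here, no measured pair shows this kind of change, so the size of its effect is unknown. The hydroxy that leaves is one of the features that sets compound 3 apart from compounds 1 and 2, and a much larger group takes its place.

The expectation is a modest step toward a higher number, a 4.0-fold higher number from compound 3 to compound 4 (0.60 log units; beyond the scatter). Compound 4 is therefore estimated at 60 nM, with a plausible range from 8 nM to 500 nM.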

Compound 4, half-maximal inhibitory concentration: 20 nM
Beside the measured number, compound 4's estimate is 3.0-fold (0.48 log units) above it; low and high end bracket the measured number.
By their numbers in this assay, from the lowest: compounds 3 and 4 (each within the scatter of the next); then compounds 2 and 1 (each within the scatter of the next).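

Putting (carboxy(4-fluorophenyl)methyl)amino in place of hydroxy on this aromatic carbon, ortho to a methoxy group, gives a 1.3-fold higher number from compound 3 to compound 4 (0.12 log units; within the scatter) in this assay and so leaves the two compounds indistinguishable. The hydroxy is therefore not required at this position for a number this low, and a group of 12 heavy atoms carrying its own aromatic ring can replace a single oxygen with no change beyond the scatter; compounds 1 and 2 could not show this, as each differs from compound 3 in more than one place. No independent measurement is available to explain why the number holds after so large a swap.

Which part of the new group matters remains open: a plain amine on this carbon would test the nitrogen alone, while a methyl ester in place of the carboxylic acid, or an unsubstituted phenyl in place of the 4-fluorophenyl, would test each of those parts in turn. As far as these compounds go, it is also open whether a small group such as a methyl, with no nitrogen or oxygen, would be accepted here as well.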